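Swapping a Carbon Bicycle for a Methoxypiperidine Urea

A few compounds are considered here, and "the series" means these few. Any claim that something is new, unique, unknown or untested is made for them only; others in the source may bear on it.

Compound 2 `O=C(C1CCC2(CCC2)CC1)N1CC(c2nc(-c3cccc(Cl)c3)no2)C1` gives 1100 nM in an assay on HEK293 cells for positive allosteric modulation of metabotropic glutamate receptor 5 (Homo sapiens), read by FLIPR (on this read-out lower numbers stand for an effect already at smaller amounts and higher numbers for an effect only at larger amounts of compound), the only actual number among the two results shown. For compound 1 `O=C(c1ccccc1F)N1CC[C@H]1c1nc(-c2cccc(F)c2)no1` the reading in this assay is a limit of the assay, > 10000 nM, not a number. Compound 3 `COC1CCCN(C(=O)N2CC(c3nc(-c4cccc(Cl)c4)no3)C2)C1` has not been measured; it differs from compound 2 by a group of 8 heavy atoms (6 carbon, 1 nitrogen, 1 oxygen; one six-membered non-aromatic ring with 1 hetero atom) in place of a group of 9 heavy atoms (9 carbon; one four-membered non-aromatic ring of carbon only, one six-membered non-aromatic ring of carbon only), on a carbonyl carbon. Within the data shown here, no step between measured compounds is available to set a scale for such a change. A modest weakening is expected, a 2.7-fold higher number from compound 2 to compound 3 (0.44 log units; beyond the scatter). Compound 3 is estimated at 3000 nM, most likely between 800 nM and 15000 nM.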

Compound 3, half-maximal effective concentration: > 10000 nM
Compound 3: a limit, no number; the forecaster's own chance of this, stated with the estimate: 30%; middle value at least 3.3-fold (0.52 log units) away from the limit.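

At this carbonyl carbon the choice of group clearly counts: in this assay, putting 3-methoxypiperidin-1-yl in place of the all-carbon group gives an at least 9.0-fold higher number from compound 2 to compound 3 (0.95 log units; beyond the scatter). That step gives only a minimum size, and the true gap stays unknown, because the reading for compound 3 is a limit and not a number: the limit of > 10000 nM in this assay, at which 2 of the 3 values shown sit.

The compounds shown leave open whether the methoxy group or the piperidine ring itself accounts for this loss. Plain piperidin-1-yl or 4-methoxypiperidin-1-yl at the same carbonyl carbon would help separate the two.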